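Swapping the benzylamine linker for a thioether

The source may report more compounds than this note shows. Statements on the series, on what has been measured and on what is new or still open speak of the compounds shown alone.

Of the compounds shown here, three built on a shared core have been tested so far: compound 1 `COc1ccc(CNc2nc3cc(N)cc(N)c3nc2-c2ccccc2)cc1OC`, compound 2 `Nc1cc(N)c2nc(-c3ccccc3)c(NCc3ccc(F)cc3)nc2c1` and compound 3 `COc1ccc(CNc2nc3cc(N)cc(N)c3nc2-c2ccccc2)cc1`. In a functional assay on TK-10 cells (Homo sapiens) for inhibition, read by sulforhodamine B assay, with a stated time of 48 h (on this read-out higher numbers stand for weaker inhibition of growth and lower numbers for stronger inhibition of growth), compound 1 gives 32400 nM, compound 2 gives 20000 nM and compound 3 gives 57500 nM. Compound 2 has the lowest of the three numbers; the step of a 1.6-fold lower number from compound 1 to compound 2 (0.21 log units; within the scatter) stays within the scatter, while a 2.9-fold higher number from compound 2 to compound 3 (0.46 log units; beyond the scatter) lies beyond it. Compound 4 `Nc1cc(N)c2nc(-c3ccccc3)c(Sc3ccc(F)cc3)nc2c1` differs from compound 2 by (4-fluorophenyl)sulfanyl in place of (4-fluorobenzyl)amino on an aromatic carbon. Among the measured compounds shown here, none of the measured steps changes this part of the molecule, so no step bears directly on the new link; each of them varied only the pendant ring. Without such a precedent, the step of a 1.3-fold higher number from compound 2 to compound 4 (0.10 log units; within the scatter) is expected to stay small, and compound 4 is estimated at 25000 nM, within the range 8000 nM to 80000 nM.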

Compound 4, concentration for total growth inhibition: < 100000 nM
Compound 4 ended at the assay's limit (the forecaster's own chance of this, stated with the estimate: 15%); the middle value is on the limit's open side.
By their numbers in this assay, from the lowest: compounds 2, 1 and 3 (each within the scatter of the next, the first and the last beyond it).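

In this assay compound 4 gives < 100000 nM as a limit of the assay, not a number, so the step from compound 2 to compound 4 cannot be read. Going by these compounds, whether (4-fluorophenyl)sulfanyl in place of (4-fluorobenzyl)amino brings stronger or weaker inhibition of growth stays open.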